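Replacing a Ring Hydrogen with Benzyl: An Expected Potency Shift

The source may hold more compounds than are shown below. What is called first, only, known or untested is meant among the compounds shown, and "the series" means these compounds.

Measured so far:
- compound 1 `CC(=O)N[C@@H]1[C@@H](OC(C)=O)[C@H](OC(C)=O)[C@@H](COC(C)=O)O[C@H]1n1nc(-c2cc3ccccc3[nH]2)nc1SCc1ccccc1`: > 100 ug/mL in a functional assay on MCF7 cells (Homo sapiens) for antiproliferative activity, read by sulforhodamine B assay, with a stated time of 48 h; a higher number here means a weaker inhibitor, a lower number a stronger inhibitor
- compound 2 `c1ccc(CSc2nc(-c3cc4ccccc4[nH]3)n[nH]2)cc1`: 4.53 ug/mL in this assay

For the measured compounds named here, compound 2 gives 4.53 ug/mL in this assay, the only numerical value recorded in the set. Going by the values given here, for compound 1 the result is a limit rather than a number, as the value > 100 ug/mL shows; compound 2 is therefore the one compound with a measured figure to build on, and the limit of compound 1 the limit of > 100 ug/mL in this assay, at which 1 of the 2 values shown sits, is the only other point of reference.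

Compound 3 `c1ccc(CSc2nc(-c3cc4ccccc4[nH]3)nn2Cc2ccccc2)cc1` has not yet been measured. It differs from compound 2 by benzyl in place of hydrogen on an aromatic nitrogen. Among the compounds with values here, no measured pair in the set shows the effect of this exact change, so the step from compound 2 to compound 3 cannot be read from data; it can only be estimated. The expectation is a modest weakening, with the step of a 1.8-fold higher number from compound 2 to compound 3 (0.25 log units; within the scatter) possibly no larger than the usual scatter. Compound 3 is thus estimated at 8 ug/mL, within a range from 3 ug/mL to 30 ug/mL.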

Compound 3, half-maximal inhibitory concentration: 10.8 ug/mL
Compound 3: the middle estimate sits 1.4-fold (0.13 log units) below what was measured, and the stated range covers the measured number.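

Putting benzyl on this aromatic nitrogen has a price, but a limited one: this assay shows a 2.4-fold higher number from compound 2 to compound 3 (0.38 log units; beyond the scatter), a modest step that still lies beyond the usual scatter. The hydrogen on this nitrogen is therefore not needed for a measurable result, and filling the position does not by itself remove the antiproliferative effect, since compound 3 still gives 10.8 ug/mL. Compound 1, which carries a far larger group on the same aromatic nitrogen, gives only a limit and not a number: the limit of > 100 ug/mL in this assay, at which 1 of the 3 values shown sits.

The steps that involve compound 1 cannot be read as sizes, so the compounds shown do not tell how far the loss goes as the group on this nitrogen grows, nor whether the six-membered aromatic ring of benzyl matters at all. A small methyl group, a longer plain carbon chain, or a chain ending in an amine or a carboxylic acid on this nitrogen would each test whether the modest step seen here holds for other groups or belongs to benzyl alone.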